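Lengthening the Side Chain on a Toll-like Receptor 8 Agonist

The compounds below may be only part of what the source reports. "The series", "measured", "known", "first", "only" and "open" are said of these compounds alone.

Compound 1, `CCC[C@@H](CO)Nc1nc(N)nc2cccnc12`, and compound 2, `CCCC[C@@H](CO)Nc1nc(N)nc2cccnc12`, share one core and differ only by methyl in place of hydrogen on a saturated chain carbon, four bonds along the chain from a nitrogen on an aromatic ring. In an assay on tissue (PBMC cells) for agonist activity at Toll-like receptor 8 (Homo sapiens), with a stated time of 24 h (a higher number here means that more compound is needed for the effect, a lower number that less compound is needed), compound 1 gives 430 nM, and in this assay compound 2 gives 420 nM, so that a 1.0-fold lower number from compound 1 to compound 2 (0.01 log units; within the scatter). Compound 3, `CCCCC[C@](C)(CO)Nc1nc(N)nc2cccnc12`, carries a core whose difference from that of compound 1 is not broken down here; in this assay compound 3 gives 580 nM, a number within the scatter of both compound 1 and compound 2. Compound 4, `CCCCCC[C@](C)(CO)Nc1nc(N)nc2cccnc12`, has not yet been measured. It differs from compound 3 by methyl in place of hydrogen on a saturated chain carbon, six bonds along the chain from a nitrogen on an aromatic ring. Among the compounds with values here, this is the same kind of change as the one from compound 1 to compound 2, but not the same: there the new methyl sat four bonds along the chain from a nitrogen on an aromatic ring, here it sits six bonds along the chain from a nitrogen on an aromatic ring. The expectation for compound 4 rests on the step of a 1.0-fold lower number from compound 1 to compound 2 (0.01 log units; within the scatter), where the same kind of change left the number within the scatter. The step from compound 3 to compound 4 is therefore expected to be small, a 1.0-fold lower number from compound 3 to compound 4 (0.02 log units; within the scatter). On that basis compound 4 is estimated to give 560 nM in this assay, with a likely range from 260 nM to 1200 nM.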

Compound 4, half-maximal effective concentration: 10000 nM
Beside the measured number, compound 4's estimate is 18-fold (1.25 log units) below it; the measured number lies above the stated range.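

In this assay, methyl in place of hydrogen on a saturated chain carbon, six bonds along the chain from a nitrogen on an aromatic ring, gives a 17-fold higher number from compound 3 to compound 4 (1.24 log units; beyond the scatter), so on the core of compound 3 this small change matters a great deal. Set beside the earlier step, the result shows that the change does not carry over unaltered from one core to the other in this series: the same change on two cores in this assay, a 1.0-fold lower number (0.01 log units; within the scatter) from compound 1 to compound 2 and a 17-fold higher number (1.24 log units; beyond the scatter) from compound 3 to compound 4, 18-fold (1.25 log units) apart, beyond the scatter of two such steps What this does not show is why the two steps part ways, and it gives no general rule: there is only one pair on each side, and the two pairs differ both in the core and in how far along the chain the new methyl sits, so the two influences cannot be told apart.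

The compounds shown leave open whether the same lengthening to six bonds along the chain would also raise the number sharply on the core of compound 1. They also leave open what a longer chain, or a chain ending in an amine or a carboxylic acid, would do on the core of compound 3.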